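A Change on Sulfur in a Growth Inhibitor Series

The compounds below may be only part of what the source reports. "The series", "measured", "known", "first", "only" and "open" are said of these compounds alone.

Of the compounds shown here, two have been measured so far in a functional assay on DU-145 cells (Homo sapiens) for inhibition, read by trypan blue exclusion, with a stated time of 96 h; a lower number here means a stronger inhibitor of growth, a higher number a weaker inhibitor of growth. Compound 1 (`O=C(/C(=C\c1ccc(Br)cc1)SCc1ccc(Cl)cc1)c1ccc(Cl)cc1`) gives 1000 nM, and compound 2 (`Cc1ccc(S/C(=C/c2cc(C)cc(C)c2)C(=O)c2ccc(Cl)cc2)cc1`) gives 50000 nM. Compound 2 therefore holds the higher of the two numbers and is the weaker inhibitor of growth, by a margin well beyond the scatter. Compound 3 (`Cc1cc(C)cc(/C=C(/SCc2ccc(Cl)cc2)C(=O)c2ccc(Cl)cc2)c1`) has yet to be measured in this assay. It departs from compound 2 in one place: 4-chlorobenzyl in place of 4-methylphenyl on a sulfur. In words, 4-chlorobenzyl stands in place of 4-methylphenyl on a sulfur. Among the compounds with values here, compound 1 also carries 4-chlorobenzyl on its sulfur, but it differs from compound 2 in more than one place, so no measured step isolates this change. Compound 1 nevertheless gives 1000 nM, so a lower number is expected for compound 3, with a step beyond the scatter but probably not the whole gap between the two measured compounds. The expected move is a 10-fold lower number from compound 2 to compound 3 (1.00 log units; beyond the scatter). For compound 3 the estimated value is 5000 nM, with an expected range of 1200 nM to 25000 nM.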

Compound 3, concentration for 50% growth inhibition: 10000 nM
The estimate for compound 3 lay 2.0-fold (0.30 log units) below the measured number; low and high end bracket the measured number.
By their numbers in this assay, from the lowest: compound 1; then compound 3; then compound 2.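

In this assay, 4-chlorobenzyl in place of 4-methylphenyl, on a sulfur whose other neighbour is a double-bonded chain carbon, gives a 5.0-fold lower number from compound 2 to compound 3 (0.70 log units; beyond the scatter). Within the data shown here, this is the first step that isolates a change on this sulfur, and it shows that the group there matters on its own, apart from the other differences between the earlier compounds. With 4-chlorobenzyl held on the sulfur, 3,5-dimethylphenyl in place of 4-bromophenyl on a double-bonded chain carbon bound to a double-bonded chain carbon gives a 10-fold higher number from compound 1 to compound 3 (1.00 log units; beyond the scatter), so that second place also moves the number, and no measurement shown here accounts for either step.

The change on the sulfur swaps two features at once, and the compounds shown do not tell whether the chlorine or the added carbon of the benzyl group goes with the lower number; 4-chlorophenyl and 4-methylbenzyl on the sulfur would separate the two. Going by these compounds, it also remains open how a carboxylic acid or an amine in place of the chlorine on the benzyl group would read in this assay.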